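Cyclohexyl Ether in Place of a Fluorophenyl Ether

This account rests on a few compounds, and the source may have more. Where it says the series, first, only, none or still open, it means among the compounds named here.

Three compounds share one core, and two of them have been tested in an ADME assay on MRC5 cells (Homo sapiens) for cytotoxicity, read by fluorescence and resazurin assay, with a stated time of 3 days; a higher number here means a weaker inhibitor, a lower number a stronger inhibitor. Compound 1 `Cc1cn(C2CCN(Cc3cccc(Oc4ccccc4)n3)CC2)c(=O)[nH]c1=O` gives in this assay only a limit of the measurement, > 64000 nM. Compound 2 `Cc1cn(C2CCN(Cc3cccc(Oc4cccc(F)c4)c3)CC2)c(=O)[nH]c1=O` likewise reaches in this assay only a limit, > 64000 nM. For compound 3 `Cc1cn(C2CCN(Cc3cc(Oc4cc(Cl)cc(Cl)c4)ccn3)CC2)c(=O)[nH]c1=O` this assay reports "not determined" (no result reported), so no result is available for it. Compound 2 therefore stands at the limit of > 64000 nM in this assay, at which 2 of the 3 values shown sit, and nothing in the numbers so far sets it apart from compound 1; no single measured step exists between any two of these compounds.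

The next compound, compound 4 `Cc1cn(C2CCN(Cc3cccc(OC4CCCCC4)c3)CC2)c(=O)[nH]c1=O`, is to be tested in this assay. It differs from compound 2 in one place: cyclohexyl in place of 3-fluorophenyl on an oxygen on an aromatic ring.

Among the measured compounds shown here, no measured step is available to show how this kind of exchange moves the read-out, so the expectation can only rest on where compound 2 sits. Because compound 2 reaches only the limit > 64000 nM, compound 4 is expected to behave the same way and to give no measurable number. The step from this estimate, a number no higher from compound 2 to compound 4 (the limit leaves the size open), is expected to be none beyond the scatter. Compound 4 is thus estimated at 64000 nM, most likely again as a limit, with a range from 20000 nM to 150000 nM.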

Compound 4, half-maximal inhibitory concentration: 23600 nM
Compound 4: the middle estimate sits 2.7-fold (0.43 log units) above what was measured, within the range that was stated.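

At this position, on an oxygen on an aromatic ring, the exchange of 3-fluorophenyl for cyclohexyl produces a real number in this assay, and the change reads as an at least 2.7-fold lower number from compound 2 to compound 4 (0.43 log units; beyond the scatter). The group on this oxygen therefore matters for the read-out: replacing one six-membered ring of carbon with another, now non-aromatic and without the fluorine, moves the result beyond the usual scatter. The step can only be given as a minimum because one end of it is not a number, and its true size stays unknown: the limit of > 64000 nM in this assay, at which 2 of the 4 values shown sit.

The exchange removes the fluorine and the aromatic ring together, so these compounds cannot show which of the two accounts for the shift, and they give no reason for it. How a 3-fluorocyclohexyl group, a smaller cyclopentyl ring or an open butyl chain on the same oxygen would read in this assay remains open, as does whether the same exchange would have a similar effect on the other cores shown.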